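The compounds below may be only part of what the source reports. "The series", "measured", "known", "first", "only" and "open" are said of these compounds alone.

Measured so far: compound 1 `O=C(CCCC1CCN(C(=O)c2ccccc2)CC1)c1ncco1`, in an assay on isolated protein for inhibition of Fatty-acid amide hydrolase 1 (Homo sapiens) (on this read-out lower numbers stand for stronger inhibition and higher numbers for weaker inhibition), compound 1 gives 77 nM; compound 2 `Cc1ccc(CN2CCC(CCCC(=O)c3ncco3)CC2)cc1`, in this assay compound 2 gives 400 nM.

Going by the values given here, compound 2 stands at the highest of the two numbers; the only step available is a 5.2-fold higher number from compound 1 to compound 2 (0.72 log units; beyond the scatter). Compound 3 `O=C(CCCC1CCN(Cc2ccc(Cl)cc2)CC1)c1ncco1` differs from compound 2 by chloro in place of methyl on an aromatic carbon. Among the compounds with values here, no measured step touches this position; the one step on record concerns the group on the ring nitrogen, not the substituent on the benzyl ring, so it gives little guidance. The change is small in count, and the expected step of a 1.3-fold lower number from compound 2 to compound 3 (0.12 log units; within the scatter) is expected to stay within the scatter. Compound 3 is estimated at 300 nM, range 100 nM to 1000 nM.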

Compound 3, half-maximal inhibitory concentration: 66 nM
Compound 3: middle estimate off by 4.5-fold (0.66 log units), on the high side; the measured number lies below the stated range.
By their numbers in this assay, from the lowest: compounds 3 and 1 (each within the scatter of the next); then compound 2.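

The substituent on the benzyl ring matters in this assay: chloro in place of methyl gives a 6.1-fold lower number from compound 2 to compound 3 (0.78 log units; beyond the scatter) at this position, a clear shift from one heavy atom exchanged. With 4-chlorobenzyl in place of benzoyl on the ring nitrogen, the result is a 1.2-fold lower number from compound 1 to compound 3 (0.07 log units; within the scatter) and no more, so in this pair a benzyl group matches the benzoyl group despite lacking its carbonyl. No evidence on hand explains the shift.

Open, as far as these compounds go, is whether fluoro, bromo or trifluoromethyl at this carbon would behave like chloro. Also open, from the compounds shown here alone, is what the unsubstituted benzyl group gives.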